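Changing the Ring on the Aromatic Nitrogen of the Core

The source may report more compounds than this note shows. Statements on the series, on what has been measured and on what is new or still open speak of the compounds shown alone.

Compound 2 `COc1ccc(CCc2nc3cc(-c4c(C)noc4C)ccc3n2[C@H]2CC[C@H](C(F)(F)F)CC2)cc1Cl` gives 894 nM in an assay on isolated protein for inhibition of histone acetyltransferase p300 (Homo sapiens), read by AlphaLISA, with a stated time of 20 min (a lower number here means a stronger inhibitor, a higher number a weaker inhibitor), the higher of the two numbers measured, the other coming from compound 1 `COc1ccc(CCc2nc3cc(-c4c(C)noc4C)ccc3n2C2CCN(S(C)(=O)=O)CC2)cc1Cl`, which gives 148 nM. Within the data shown here, the single step that bears on this place was a 6.0-fold higher number from compound 1 to compound 2 (0.78 log units; beyond the scatter). Compound 3 `COc1ccc(CCc2nc3cc(-c4c(C)noc4C)ccc3n2C2CC(C)(C)OC(C)(C)C2)cc1Cl` carries 2,2,6,6-tetramethyloxan-4-yl in place of 4-(trifluoromethyl)cyclohexyl on an aromatic nitrogen. That earlier step shows the group on this nitrogen can move the number beyond the scatter, yet nothing measured tells which way a tetramethyloxanyl ring goes, so a modest downward step is expected as a 1.8-fold lower number from compound 2 to compound 3 (0.25 log units; within the scatter). Compound 3 is thus estimated at 500 nM, between 150 nM and 1800 nM.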

Compound 3, half-maximal inhibitory concentration: 112 nM
The estimate for compound 3 lay 4.5-fold (0.65 log units) above the measured number; the whole stated range lies above it.
By their numbers in this assay, from the lowest: compounds 3 and 1 (each within the scatter of the next); then compound 2.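

Swapping 4-(trifluoromethyl)cyclohexyl for 2,2,6,6-tetramethyloxan-4-yl on this aromatic nitrogen brings an 8.0-fold lower number from compound 2 to compound 3 (0.90 log units; beyond the scatter) in this assay. Set against 1-(methylsulfonyl)piperidin-4-yl, the same ring gives a 1.3-fold lower number from compound 1 to compound 3 (0.12 log units; within the scatter), so these two different rings sit level and the cyclohexyl ring of compound 2 stands apart. No available measurement explains this difference.

From the compounds shown here alone, whether a piperidine with a free ring amine, or a ring bearing a carboxylic acid, would stay at this level remains open. So does what the four methyl groups on the oxanyl ring contribute.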